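Replacing the Aryl Amine of Compound 1 with Ethoxy

The source may report more compounds than this note shows. Statements on the series, on what has been measured and on what is new or still open speak of the compounds shown alone.

Of the compounds shown here, three sharing one core have been tested in a functional assay on MCF7 cells (Homo sapiens) for inhibition, read by sulforhodamine B assay, with a stated time of 48 h; a higher number here means a weaker inhibitor of growth, a lower number a stronger inhibitor of growth. Compound 1 `COc1ccc2c(c1)NC(=O)CN2c1nc(Nc2cccc(C#N)c2)nc2ccccc12` gives 384 nM in this assay, the highest of the three numbers and therefore the weakest inhibitor of growth here. Compound 2 `COc1ccc2c(c1)NC(=O)CN2c1nc(NC2CCCC2)nc2ccccc12` gives 7.67 nM, and compound 3 `CCCCNc1nc(N2CC(=O)Nc3cc(OC)ccc32)c2ccccc2n1` gives 7.88 nM. The two measured steps away from compound 1 are both large: a 50-fold lower number from compound 1 to compound 2 (1.70 log units; beyond the scatter), and a 49-fold lower number from compound 1 to compound 3 (1.69 log units; beyond the scatter). Between compound 2 and compound 3 the change is a 1.0-fold higher number from compound 2 to compound 3 (0.01 log units; within the scatter), so swapping one small alkyl group for another made no difference.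

Compound 4 `CCOc1nc(N2CC(=O)Nc3cc(OC)ccc32)c2ccccc2n1` has not yet been measured. It differs from compound 1 in one place: ethoxy in place of (3-cyanophenyl)amino on an aromatic carbon. Within the data shown here, the measured steps show that removing the 3-cyanophenyl group from the nitrogen strongly lowers the number, but in compound 4 the nitrogen itself, with its hydrogen-bond donor, is also gone, and no measured pair tests that. A lowering from compound 1 is therefore expected, but with less confidence and probably smaller than the two measured steps; the expected step is a 3.8-fold lower number from compound 1 to compound 4 (0.58 log units; beyond the scatter). Compound 4 is estimated at 100 nM in this assay, within a range from 15 nM to 1000 nM.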

Compound 4, concentration for 50% growth inhibition: 8.59 nM
Compound 4: the middle estimate sits 12-fold (1.07 log units) above what was measured; the whole stated range lies above it.
By their numbers in this assay, from the lowest: compounds 2, 3 and 4 (each within the scatter of the next); then compound 1.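

In this assay, ethoxy in place of (3-cyanophenyl)amino gives a 45-fold lower number from compound 1 to compound 4 (1.65 log units; beyond the scatter), so the large fall in the number seen with cyclopentyl and butyl on the nitrogen does not depend on keeping that nitrogen or its hydrogen-bond donor. The linking atom can also be oxygen rather than nitrogen with no difference beyond the scatter: ethoxy in place of butylamino gives a 1.1-fold higher number from compound 3 to compound 4 (0.04 log units; within the scatter), and ethoxy in place of cyclopentylamino gives a 1.1-fold higher number from compound 2 to compound 4 (0.05 log units; within the scatter). On this aromatic carbon between two ring nitrogen atoms, the ethoxy, butylamino and cyclopentylamino groups therefore read alike, and only the (3-cyanophenyl)amino group of compound 1 stands apart from them.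

Nothing available here explains why compound 1 gives the highest number of the four, so the link between structure and growth inhibition remains purely descriptive. The compounds shown do not separate the effect of the phenyl ring from that of its nitrile, which a plain phenylamino group could do, while a benzylamino group, a longer chain such as hexyloxy or an unsubstituted amine would show how far the alkyl and ethoxy result extends.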